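A few compounds are considered here, and "the series" means these few. Any claim that something is new, unique, unknown or untested is made for them only; others in the source may bear on it.

In an ADME assay on microsomes from liver (Homo sapiens) for metabolic stability (a lower number here means slower removal, a higher number faster removal of the compound), compound 1 (`Cc1cc2ncccc2cc1Nc1ncc2c(n1)n(C1CCOCC1)c(=O)n2C`) gives 30 mL.min-1.g-1 as the highest of the three numbers in hand. Compound 2 (`Cc1cc2nnccc2cc1Nc1ncc2c(n1)n(C1CCOCC1)c(=O)n2C`) gives 14 mL.min-1.g-1 and compound 3 (`Cc1cc2nccnc2cc1Nc1ncc2c(n1)n(C1CCOCC1)c(=O)n2C`) gives 6.9 mL.min-1.g-1 and both sit lower than compound 1 by more than the scatter, with compound 3 furthest away.

The next compound to be read is compound 4 (`Cc1cc2ncccc2cc1Nc1ncc2c(n1)n(C1CCNCC1)c(=O)n2C`), which has piperidin-4-yl in place of oxan-4-yl on an aromatic nitrogen relative to compound 1. Among the compounds with values here, no measured pair contains this exchange, so the size of the step cannot be read from the data and remains a judgement. A moderate fall in this assay is expected, only slightly beyond the scatter, and a result within the scatter of compound 1 would not be surprising. The expected change is a 1.9-fold lower number from compound 1 to compound 4 (0.27 log units; within the scatter) as an estimate only. For compound 4 the estimated value is 16 mL.min-1.g-1 with an expected range from 7 mL.min-1.g-1 to 35 mL.min-1.g-1 in this read-out.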

Compound 4, intrinsic clearance in microsomes: < 4 mL.min-1.g-1
Compound 4 ended at the assay's limit; the forecaster's own chance of this, stated with the estimate: 5%; middle value at least 4.0-fold (0.60 log units) from the limit.
By their numbers in this assay, from the lowest: compound 3; then compound 2; then compound 1. At a limit, below all of these: compound 4.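

Among the compounds shown, the place on the aromatic nitrogen carries oxan-4-yl in compound 1, compound 2 and compound 3, so compound 4 gives the first reading of a change there: in this assay, piperidin-4-yl in place of oxan-4-yl gives an at least 7.5-fold lower number from compound 1 to compound 4 (0.87 log units; beyond the scatter). Compound 4 gives < 4 mL.min-1.g-1, which is a limit of the assay and not a number. The step therefore has a lower bound but no full size: the limit of < 4 mL.min-1.g-1 in this assay, at which 1 of the 4 values shown sits.

On these data alone, whether the same exchange gives a step of similar size on the cores of compound 2 and compound 3 remains open. Also open, as far as these compounds go, is whether the ring nitrogen or the hydrogen on it goes with the step, which 1-methylpiperidin-4-yl or an open-chain amine at this place could help to separate.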